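From dimethylamino to propylsulfanyl on a shared core

The source may hold more compounds than are shown below. What is called first, only, known or untested is meant among the compounds shown, and "the series" means these compounds.

Three compounds built on one shared core have entries in an ADME assay on MOLT-3 cells (Homo sapiens) for cytotoxicity, with a stated time of 7 days (on this read-out lower numbers stand for higher toxicity in this test and higher numbers for lower toxicity in this test), and only one of those entries carries a figure. Compound 3 `CN(C)c1nc(N)nc2c1ncn2/C=C1/CC1(CO)CO` stands without a number, since its entry is "not determined" (no result reported) and nothing more. Compound 1 `CC(C)CSc1nc(N)nc2c1ncn2/C=C1/CC1(CO)CO` offers no number either, with "not determined" (no result reported) as its entry. Compound 2 `COCCOc1nc(N)nc2c1ncn2/C=C1/CC1(CO)CO` gives > 20000 nM as a limit of the assay and not as a number.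

Compound 4 `CCCSc1nc(N)nc2c1ncn2/C=C1/CC1(CO)CO` has yet to be measured. The step in question is propylsulfanyl in place of dimethylamino on an aromatic carbon with propylsulfanyl in place of dimethylamino on an aromatic carbon, next to the ring nitrogen. Going by the values given here, no measured step exists in this small set, so the size of this change in this assay cannot be read from the data. The only anchor is the limit that compound 2 gives at > 20000 nM and no step beyond the usual scatter from that mark is expected in either direction. For compound 4 the half-maximal cytotoxic concentration is estimated at 20000 nM with an expected range from 7000 nM to 60000 nM and the result may well come back as a limit.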

Compound 4, half-maximal cytotoxic concentration: > 20000 nM
Compound 4: a limit, no number; the forecaster's own chance of this, stated with the estimate: 70%; the middle value lies on the limit itself.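

In this assay, going by these compounds alone, compound 2 and compound 4 both end at a limit of the assay and not at a number, so no step between them can be read, and what they share is this: the limit of > 20000 nM in this assay, at which 2 of the 4 values shown sit. The compounds shown leave open whether any group at this place on the shared core shifts the half-maximal cytotoxic concentration at all.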